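A few compounds are considered here, and "the series" means these few. Any claim that something is new, unique, unknown or untested is made for them only; others in the source may bear on it.

For the measured compounds named here, in a functional assay on K562 cells (Homo sapiens) for inhibition, read by CCK-8 assay, with a stated time of 72 h (a higher number here means a weaker inhibitor, a lower number a stronger inhibitor), compound 1 `O=C(/C=C/c1cccnc1)NCCCCCCc1cccc(S(=O)(=O)Nc2ccccc2)c1` gives 0.88 nM, the lowest of the two numbers measured so far. Going by the values given here, the only other measured compound, compound 2 `Cc1cccc(NS(=O)(=O)c2cccc(CCCCCCNC(=O)/C=C/c3cccnc3)c2)c1`, gives 4.78 nM. Compound 3 `O=C(/C=C/c1cccnc1)NCCCCCCc1cccc(S(=O)(=O)Nc2ccc(Oc3ccccc3)cc2)c1` has not yet been measured. It differs from compound 1 by a single change, phenoxy in place of hydrogen on an aromatic carbon, para to a large group. Among the compounds with values here, one measured step bears on this change, and only indirectly. That step is a 5.4-fold higher number from compound 1 to compound 2 (0.73 log units; beyond the scatter), with methyl in place of hydrogen on an aromatic carbon, and it is a modest weakening beyond the scatter. Phenoxy is a much larger group than methyl, and no measured compound carries a group of that size, so this single step is a weak guide. A weakening of similar size is still the most reasonable expectation, with a wide margin on either side. The expected change is a 4.5-fold higher number from compound 1 to compound 3 (0.66 log units; beyond the scatter). In this assay the expected value for compound 3 is 4 nM, with an estimated range of 0.8 nM to 20 nM.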

Compound 3, half-maximal inhibitory concentration: 5.12 nM
Compound 3: middle estimate off by 1.3-fold (0.11 log units), on the low side; measured number inside the range.
By their numbers in this assay, from the lowest: compound 1; then compounds 2 and 3 (each within the scatter of the next).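

In this assay, phenoxy in place of hydrogen on an aromatic carbon, para to a large group, gives a 5.8-fold higher number from compound 1 to compound 3 (0.76 log units; beyond the scatter), so a group carrying a whole six-membered aromatic ring of carbon only can stand at this place, and the step is still classed as modest. Read beside a 5.4-fold higher number from compound 1 to compound 2 (0.73 log units; beyond the scatter), it gives a second case in which a group in place of hydrogen goes with a higher number, and a group much larger than methyl is now among them, so compound 1, with only hydrogen on this ring, keeps the lowest number of the three. No measurement shown here accounts for the rise in the number with phenoxy.

As far as these compounds go, whether the number follows the size of the group at this carbon stays open, since nothing between methyl and phenoxy, such as methoxy or ethoxy, stands. From the compounds shown here alone, it is also open how a fluorine, an amine or a carboxylic acid at this place would compare with hydrogen in this assay.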